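Amide to thioester at the carbonyl of compound 1

The compounds below may be only part of what the source reports. "The series", "measured", "known", "first", "only" and "open" are said of these compounds alone.

Compound 1 `CCNC(=O)C1=C(C)NC(=O)NC1c1ccco1` shows essentially no displacement in an assay on membranes from HEK293 cells for displacement of a labelled ligand from adenosine receptor A2b (Homo sapiens), read by scintillation counting, with a stated time of 30 min, tested at 1 uM (a higher number here means more inhibition at the concentration tested (going by the name of the read-out), a lower number less inhibition), giving 1%. Compound 2 `CCNC(=O)C1=C(C)NC(=O)NC1c1cccs1` gives 1% and compound 3 `CCNC(=O)C1=C(C)NC(=O)NC1c1ccsc1` gives 1% in this assay, so all three stand level: no change at the digits printed from compound 1 to compound 2 (within the scatter), no change at the digits printed from compound 1 to compound 3 (within the scatter) and no change at the digits printed from compound 2 to compound 3 (within the scatter). Compound 4 `CC1=C(C(=O)SC(C)C)C(c2ccco2)NC(=O)N1` differs from compound 1 in isopropylsulfanyl in place of ethylamino on a carbonyl carbon. Among the measured compounds shown here, no measured step touches the carbonyl carbon; all three vary the ring on the saturated ring carbon and leave the read-out unchanged, so they give no guide to the size of this change, only the level at which the series sits. With nothing pointing upward, compound 4 is expected to stay near that level, a step of a number 2 percentage points higher from compound 1 to compound 4 (within the scatter). The estimate for compound 4 is 3%, within -10% to 20%.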

Compound 4, a percentage reported as inhibition, at one concentration (the size of the read-out at that concentration, not a potency): 22%
Beside the measured number, compound 4's estimate is 19 percentage points below it; measured number outside the range, above it.
By their numbers in this assay, from the lowest: compounds 1, 2 and 3 (each within the scatter of the next); then compound 4.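

The carbonyl carbon is a position where this assay responds, as a number 21 percentage points higher from compound 1 to compound 4 (beyond the scatter) follows from isopropylsulfanyl in place of ethylamino, whereas changing the ring on the saturated ring carbon left the read-out flat. This single change alters the sulfur, the chain and the hydrogen-bond donor together, so the step cannot be assigned to any one of them. Nothing measured here accounts for the rise.

Open, on these data alone, is whether isopropylamino or ethylsulfanyl on this carbonyl carbon would carry the step. Also open, as far as these compounds go, is whether it holds with thiophen-2-yl or thiophen-3-yl in place of furan-2-yl.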